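The compounds below may be only part of what the source reports. "The series", "measured", "known", "first", "only" and "open" are said of these compounds alone.

Working notes on the sulfonamide series, step from compound 3 to compound 4.

Compound 3 `Cc1ccc(S(=O)(=O)N2CC=C(Br)CC2)cc1` carries a bromo group on the double-bonded ring carbon of the shared core. In a functional assay on A2780 cells (Homo sapiens) for antiproliferative activity, read by sulforhodamine B assay, with a stated time of 48 h (on this read-out higher numbers stand for weaker inhibition of growth and lower numbers for stronger inhibition of growth), compound 3 gives only a limit, > 100000 nM. Compound 1 `Cc1ccc(S(=O)(=O)N2CC=C(Cl)CC2)cc1`, the chloro analogue, likewise gives only a limit in this assay, > 100000 nM. The step that the two limits leave unreadable from compound 1 to compound 3 therefore cannot be read, since both values sit at the limit of > 100000 nM in this assay, at which 2 of the 3 values shown sit. Compound 2 `Cc1ccc(S(=O)(=O)N2CCC(Cl)=CC2CC(C)C)cc1` is the analogue in which an isobutyl group has entered on a saturated ring carbon of the shared core; in this assay compound 2 gives 35000 nM, and the step of an at least 2.8-fold lower number from compound 1 to compound 2 (0.45 log units; beyond the scatter) is the only readable one in the set.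

Compound 4 `Cc1ccc(S(=O)(=O)N2CCC(Br)=CC2CC(C)C)cc1` is the corresponding isobutyl analogue of compound 3. The change is isobutyl in place of hydrogen on a saturated ring carbon. The same change, made on the chloro compound, gave an at least 2.8-fold lower number from compound 1 to compound 2 (0.45 log units; beyond the scatter), a lowering of the number that is at least modest; the bromo-for-chloro swap itself is unreadable. Compound 4 is therefore expected to leave the limit and land near compound 2, which means an expected step of an at least 2.8-fold lower number from compound 3 to compound 4 (0.45 log units; beyond the scatter). The estimate for compound 4 in this assay is 35000 nM, with a range from 12000 nM to 100000 nM.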

Compound 4, concentration for 50% growth inhibition: 36000 nM
Estimate against measurement, compound 4: 1.0-fold (0.01 log units) below; low and high end bracket the measured number.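

In this assay, isobutyl in place of hydrogen on the saturated ring carbon next to the ring nitrogen now also gives a readable step on the bromo compound, an at least 2.7-fold lower number from compound 3 to compound 4 (0.44 log units; beyond the scatter), so the change seen on the chloro compound recurs on a second core: the same change on two cores in this assay, an at least 2.8-fold lower number (0.45 log units; beyond the scatter) from compound 1 to compound 2 and an at least 2.7-fold lower number (0.44 log units; beyond the scatter) from compound 3 to compound 4; the limit leaves it open whether they differ

Within the data shown here, with isobutyl in place, the bromo-for-chloro swap can be read for the first time, a 1.0-fold higher number from compound 2 to compound 4 (0.01 log units; within the scatter), and at this position on the core the two halogens are not told apart in this assay.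

Without isobutyl the same swap still cannot be read, and the isobutyl step on each core is known only as a bound: the limit of > 100000 nM in this assay, at which 2 of the 4 values shown sit.

Whether a longer chain, a benzyl group or a chain ending in an amine or a carboxylic acid at this saturated ring carbon would move the number further remains open, since isobutyl is the only group shown there. Also open, as far as these compounds go, is whether a group other than a halogen on the double-bonded ring carbon, such as a methyl or a nitrile, would keep the number seen with chloro and bromo.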